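Swapping the benzyl group on a shared core

The source may hold more compounds than are shown below. What is called first, only, known or untested is meant among the compounds shown, and "the series" means these compounds.

Measured so far:
compound 1, `COc1cccc(CNCCCNc2ccnc3cc(C4CCCCC4)ccc23)c1O`: 9.47
compound 2, `COc1cccc(Oc2ccc3c(NCCCNCc4cc(F)ccc4OC)ccnc3c2)c1`: 9.28

In a physicochemical assay for acid dissociation, compound 2 gives 9.28. Among the compounds with values here, the only other number in this assay comes from compound 1, whose 9.47 lies within the usual scatter of the value of compound 2, so the two cannot be told apart on these data.

Compound 3, `COc1cccc(Oc2ccc3c(NCCCNCc4cccc(OC)c4O)ccnc3c2)c1`, is not yet measured in this assay. It differs from compound 2 in one place: 2-hydroxy-3-methoxyphenyl in place of 5-fluoro-2-methoxyphenyl on a saturated chain carbon bound to an amine nitrogen. Within the data shown here, no measured pair shows this exact step on this core, so its size is not known from the data. Among the measured compounds shown here, the group that enters is the one carried by compound 1, and because in this assay compound 1 gives 9.47 the step from compound 2 to compound 3 is expected to be small, at most a slight rise, estimated as a number 0.17 log units higher from compound 2 to compound 3 (within the scatter). For compound 3 in this assay the value is estimated at 9.45, with a range from 9.15 to 9.75.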

Compound 3, acid dissociation constant: 9.28
Estimate against measurement, compound 3: 0.17 log units above, within the range that was stated.
By their numbers in this assay, from the lowest: compounds 2, 3 and 1 (each within the scatter of the next).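

In this assay, within the data shown here, the swap of 5-fluoro-2-methoxyphenyl for 2-hydroxy-3-methoxyphenyl on a saturated chain carbon bound to an amine nitrogen gives no change at the digits printed from compound 2 to compound 3 (within the scatter), the first measured step at this position, and it shows that this exchange leaves the read-out unmoved within the scatter. With 2-hydroxy-3-methoxybenzyl held fixed, the change elsewhere on the shared core, 3-methoxyphenoxy in place of cyclohexyl on an aromatic carbon, gives a number 0.19 log units lower from compound 1 to compound 3 (within the scatter), so neither single change separates these compounds. Nothing available gives a reason for either result.

Both groups compared at this position are substituted benzyl groups. From the compounds shown here alone, how the read-out would respond to a carboxylic acid or a second amine in their place, or to a longer chain, stays open.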